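The source may hold more compounds than are shown below. What is called first, only, known or untested is meant among the compounds shown, and "the series" means these compounds.

Measured so far in a functional assay, with a stated time of 30 min, in the absence of a further agent; on this read-out lower numbers stand for stronger inhibition and higher numbers for weaker inhibition:
- compound 1 `O=C(/C=C/c1ccc(O)c(O)c1)OCCOc1no[n+]([O-])c1S(=O)(=O)c1ccccc1` gives 42000 nM
- compound 2 `O=C(/C=C/c1ccc(O)cc1)OCCOc1no[n+]([O-])c1S(=O)(=O)c1ccccc1` gives 1390000 nM
- compound 3 `O=C(OCCOc1no[n+]([O-])c1S(=O)(=O)c1ccccc1)c1ccc(O)c(O)c1` gives 60000 nM

Compound 2 has the highest number of the three, and its steps to both others lie beyond the scatter, so it is the weakest inhibitor here. Compound 4 `COc1cc(/C=C/C(=O)OCCOc2no[n+]([O-])c2S(=O)(=O)c2ccccc2)ccc1O` differs from it in one place: methoxy in place of hydrogen on an aromatic carbon, ortho to a hydroxy group.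

Among the measured compounds shown here, no measured compound carries a methoxy group, so the evidence is indirect. The nearest comparison is a 33-fold higher number from compound 1 to compound 2 (1.52 log units; beyond the scatter), where hydrogen takes the place of hydroxy on an aromatic carbon. Read in reverse, it links a hydroxy group there with a much lower number. The step of a 23-fold lower number from compound 2 to compound 3 (1.36 log units; beyond the scatter) is also large and points the same way, while a 1.4-fold higher number from compound 1 to compound 3 (0.15 log units; within the scatter) stays within the scatter. Methoxy is not hydroxy, so only part of that gain is expected in this assay, giving an expected 4.6-fold lower number from compound 2 to compound 4 (0.67 log units; beyond the scatter) toward stronger inhibition. Compound 4 is estimated at 300000 nM, with an expected range from 70000 nM to 1300000 nM.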

Compound 4, half-maximal inhibitory concentration: 181000 nM
Estimate against measurement, compound 4: 1.7-fold (0.22 log units) above; low and high end bracket the measured number.
By their numbers in this assay, from the lowest: compounds 1 and 3 (each within the scatter of the next); then compound 4; then compound 2.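

In this assay, among the compounds shown here, the earlier compounds showed only a hydroxy group at this position, and the methoxy group shows that a hydroxy group is not the only group linked to a lower number here, with a 7.7-fold lower number from compound 2 to compound 4 (0.89 log units; beyond the scatter) on adding it ortho to the existing hydroxy group. Methoxy does not fully match hydroxy, however, as placing a methyl on that oxygen gives a 4.3-fold higher number from compound 1 to compound 4 (0.63 log units; beyond the scatter). This leaves compound 4 between compound 1 and compound 2. Nothing measured here gives a reason for either step.

On these data alone, it remains open whether a larger ethoxy group, a chlorine atom or an amine at this position would fall nearer compound 1 or compound 2. Also open, as far as these compounds go, is whether methoxy would have a similar effect in the benzoate ester series of compound 3.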